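Amide cap variation on the shared core

The compounds below may be only part of what the source reports. "The series", "measured", "known", "first", "only" and "open" are said of these compounds alone.

Measured so far in a functional assay on A549 cells (Homo sapiens) for inhibition, read by MTT assay, with a stated time of 48 h; a higher number here means a weaker inhibitor, a lower number a stronger inhibitor:
- compound 1 `O=C(CC1CCOCC1)Nc1ccc(N2CCN(c3ccc(OC[C@@H]4CO[C@@](Cn5cncn5)(c5ccc(Cl)cc5Cl)O4)cc3)CC2)cc1`: 10000 nM
- compound 2 `O=C(CCCCc1ccccc1)Nc1ccc(N2CCN(c3ccc(OC[C@@H]4CO[C@@](Cn5cncn5)(c5ccc(Cl)cc5Cl)O4)cc3)CC2)cc1`: 2610 nM
- compound 3 `O=C(Nc1ccc(N2CCN(c3ccc(OC[C@@H]4CO[C@@](Cn5cncn5)(c5ccc(Cl)cc5Cl)O4)cc3)CC2)cc1)C(/C=C/Cl)C/C=C/C(F)(F)F`: 3830 nM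

Compound 2 carries the lowest number of the three, but its separation from compound 3 is a 1.5-fold higher number from compound 2 to compound 3 (0.17 log units; within the scatter), so the two cannot be ordered. It is clearly set off from compound 1, the step being a 3.8-fold lower number from compound 1 to compound 2 (0.58 log units; beyond the scatter). Compound 3 is likewise set off from compound 1 by a 2.6-fold lower number from compound 1 to compound 3 (0.42 log units; beyond the scatter).

Compound 4 `O=C(Nc1ccc(N2CCN(c3ccc(OC[C@@H]4CO[C@@](Cn5cncn5)(c5ccc(Cl)cc5Cl)O4)cc3)CC2)cc1)c1ccco1` differs from compound 2 by furan-2-yl in place of 4-phenylbutyl on a carbonyl carbon.

Bearing on this are the two steps away from compound 1, both modest and both lowering the number when the oxanyl-bearing chain was exchanged for a longer chain on the carbonyl carbon, and the step from compound 2 to compound 3, which stayed within the scatter. Among the compounds with values here, no measured step exchanges a chain for a ring bound directly to the carbonyl carbon, so the direction for compound 4 rests only on compound 1 having the highest number with the smallest, heteroatom-bearing cap. A modest rise is expected, the estimated step being a 2.3-fold higher number from compound 2 to compound 4 (0.36 log units; beyond the scatter). Compound 4 is therefore expected to give 6000 nM, within 2500 nM to 15000 nM.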

Compound 4, half-maximal inhibitory concentration: 10500 nM
Compound 4: the middle estimate sits 1.8-fold (0.24 log units) below what was measured; the measured number falls inside the stated range.
By their numbers in this assay, from the lowest: compounds 2 and 3 (each within the scatter of the next); then compounds 1 and 4 (each within the scatter of the next).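

In this assay, furan-2-yl on the carbonyl carbon, a ring bound directly there, does not keep the level of the longer caps: the exchange for 4-phenylbutyl gives a 4.0-fold higher number from compound 2 to compound 4 (0.60 log units; beyond the scatter) and the exchange for the branched chloroethenyl and trifluoropentenyl cap gives a 2.7-fold higher number from compound 3 to compound 4 (0.44 log units; beyond the scatter) in the same direction. Against (oxan-4-yl)methyl the exchange gives a 1.1-fold higher number from compound 1 to compound 4 (0.02 log units; within the scatter) so these two caps cannot be ordered, and among the four compounds the two caps holding a ring oxygen carry the higher numbers, with no compound going against this. Nothing measured here explains these steps.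

Still open, on these data alone, is whether the ring oxygen or the smaller cap goes with the higher numbers, since furan-2-yl differs from 4-phenylbutyl in both. Cyclohexyl on the carbonyl carbon and 4-(furan-2-yl)butyl in the same place would separate the two.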